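The source may report more compounds than this note shows. Statements on the series, on what has been measured and on what is new or still open speak of the compounds shown alone.

For the measured compounds named here, compound 3 `COc1ccc(N)c(C(=O)CCNC(=O)C2CCCC2)c1` gives 0.61% in an assay for inhibition of Nitric oxide synthase, inducible (Homo sapiens), read by scintillation counting, with a stated time of 30 min, tested at 1 mM; a higher number here means more inhibition at the concentration tested (going by the name of the read-out), a lower number less inhibition; of the three numbers measured so far it stands second highest, nearest to compound 2 `CCC(=O)NCCC(=O)c1cc(OC)ccc1N` at 0.24% and furthest from compound 1 `COc1ccc(N)c(C(=O)CCNC(C)=O)c1` at 30.7%. Compound 4 `COc1ccc(N)c(C(=O)CCNC(=O)C2CCCCC2)c1` differs from compound 3 by cyclohexyl in place of cyclopentyl on a carbonyl carbon. Of the measured steps, a number 0.4 percentage points higher from compound 2 to compound 3 (within the scatter) is the closest in kind, a change of group on the same carbonyl carbon, and it stayed within the scatter; a number 30.1 percentage points lower from compound 1 to compound 3 (beyond the scatter) also touched that carbonyl carbon, but started from the much smaller methyl. The cyclohexyl in compound 4 is therefore expected to give a number 0.4 percentage points higher from compound 3 to compound 4 (within the scatter) in this assay, a step within the scatter. For compound 4 the estimate is 1%, with a range from 0% to 8%.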

Compound 4, a percentage reported as inhibition, at one concentration (the size of the read-out at that concentration, not a potency): 9.24%
Beside the measured number, compound 4's estimate is 8.2 percentage points below it, and the stated range ends below it.
By their numbers in this assay, from the lowest: compounds 2, 3 and 4 (each within the scatter of the next); then compound 1.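

Cyclohexyl on this carbonyl carbon, whose other neighbour is the amide-type nitrogen, stays level with cyclopentyl and ethyl in this assay: a number 8.6 percentage points higher from compound 3 to compound 4 (within the scatter) and a number 9 percentage points higher from compound 2 to compound 4 (within the scatter). Against methyl the change remains beyond the scatter, though modest: a number 21.5 percentage points lower from compound 1 to compound 4 (beyond the scatter), so among these four compounds only compound 1 stands apart. No evidence at hand accounts for this.

Going by these compounds, whether an amine or a carboxylic acid on this carbonyl carbon would stay level with compound 4 or approach compound 1 remains open. On these data alone, a phenyl group here is equally open.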